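A few compounds are considered here, and "the series" means these few. Any claim that something is new, unique, unknown or untested is made for them only; others in the source may bear on it.

Compound 3 `CC(C)C[C@H](NC(=O)OCC1CCC(F)(F)CC1)C(=O)N[C@@H](C[C@@H]1CCNC1=O)C(O)S(=O)(=O)O` shares its core with compound 1 `CCCC1CCC(OC(=O)N[C@@H](CC(C)C)C(=O)N[C@@H](C[C@@H]2CCNC2=O)C(O)S(=O)(=O)O)CC1` and compound 2 `CC(C)C[C@H](NC(=O)OC1CCC(F)(F)CC1)C(=O)N[C@@H](C[C@@H]1CCNC1=O)C(O)S(=O)(=O)O`; the three differ only in the group on the oxygen next to the carbonyl group. In a toxicity assay on L929 cells (Mus musculus) for cytotoxicity (a lower number here means that less compound is tolerated, a higher number that more compound is tolerated), compound 3 reaches only the limit of the assay, > 100000 nM, not a number. Compound 1 likewise gives the limit > 100000 nM in this assay. Compound 2 also gives the limit > 100000 nM in this assay. Because all three sit at the limit of > 100000 nM in this assay, at which 3 of the 3 values shown sit, the steps between them cannot be read: a step that the two limits leave unreadable from compound 1 to compound 2, a step that the two limits leave unreadable from compound 1 to compound 3 and a step that the two limits leave unreadable from compound 2 to compound 3 each stay hidden behind the two limits.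

Compound 4 `CC(C)C[C@H](NC(=O)OC1CCCCC1)C(=O)N[C@@H](C[C@@H]1CCNC1=O)C(O)S(=O)(=O)O` is the next compound, not yet measured. It differs from compound 3 in one place: cyclohexyl in place of (4,4-difluorocyclohexyl)methyl on an oxygen next to a carbonyl group. The same step, cut one bond further out, reads (4,4-difluorocyclohexyl)methoxy to cyclohexyloxy.

The measured steps bearing on this change all lie unreadable at the limit, so they give no size and no direction. The expectation is therefore no step beyond the scatter, a step that the limit leaves unreadable from compound 3 to compound 4, and compound 4 is estimated to sit at 150000 nM, most likely again reported only as a limit, within a range from 50000 nM to 500000 nM.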

Compound 4, half-maximal cytotoxic concentration: > 100000 nM
Compound 4: a limit, no number; the forecaster's own chance of this, stated with the estimate: 85%; the middle value is on the limit's open side.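

In this assay compound 4 gives > 100000 nM as a limit and not a number. Among the compounds shown here, no step among compound 1, compound 2, compound 3 and compound 4 can be read, because all four stop at the same limit: (the limit of > 100000 nM in this assay, at which 4 of the 4 values shown sit). In this assay the compounds shown leave open how much of each is actually tolerated and whether the groups on the oxygen differ at all.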